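Chloro to methyl on the benzyl ring of compound 3

The source may report more compounds than this note shows. Statements on the series, on what has been measured and on what is new or still open speak of the compounds shown alone.

Measured compounds:
compound 1, `O=C1C(=O)N(Cc2ccc(Br)cc2)c2c(F)cccc21`, in a functional assay on CHO cells for positive allosteric modulation of muscarinic acetylcholine receptor M5 (Homo sapiens), read by calcium flux (a lower number here means that less compound is needed, a higher number that more compound is needed for the effect), compound 1 gives 1930 nM
compound 2, `COc1cccc(CN2C(=O)C(=O)c3cc(OC(F)(F)F)ccc32)c1`, compound 2 gives 1700 nM
compound 3, `O=C1C(=O)N(Cc2ccccc2Cl)c2ccc(OC(F)(F)F)cc21`, compound 3 gives 4070 nM

Compound 3 stands at the highest of the three numbers; compound 1 is the nearest of the other two, and compound 2 the furthest, both beyond the scatter. Among the compounds with values here, the only single-point step among the measured compounds is a 2.4-fold higher number from compound 2 to compound 3 (0.38 log units; beyond the scatter), which exchanges one substituted benzyl for another.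

Compound 4, `Cc1ccccc1CN1C(=O)C(=O)c2cc(OC(F)(F)F)ccc21`, differs from compound 3 by methyl in place of chloro on an aromatic carbon. Within the data shown here, no measured pair isolates this exchange. The step of a 2.4-fold higher number from compound 2 to compound 3 (0.38 log units; beyond the scatter) swaps both the substituent and its position on the ring at once and therefore cannot be read as a guide to chloro against methyl at the same carbon. With nothing bearing directly on the change, the expected step is a 1.2-fold lower number from compound 3 to compound 4 (0.07 log units; within the scatter), that is, no movement beyond the scatter. Compound 4 is accordingly estimated at 3500 nM, within 1400 nM to 9000 nM.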

Compound 4, half-maximal effective concentration: 3280 nM
The estimate for compound 4 lay 1.1-fold (0.03 log units) above the measured number; the range from low to high includes it.
By their numbers in this assay, from the lowest: compounds 2, 1, 4 and 3 (each within the scatter of the next, the first and the last beyond it).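

In this assay, within the data shown here, swapping chloro for methyl, ortho to a large group, gives a 1.2-fold lower number from compound 3 to compound 4 (0.09 log units; within the scatter) and so offers the first direct reading of this exchange: the two groups cannot be told apart here. Replacing the 3-methoxyphenyl of compound 2 with 2-methylphenyl gives a 1.9-fold higher number from compound 2 to compound 4 (0.29 log units; within the scatter) and also stays within the scatter, so this benzyl change, unlike the 2-chlorophenyl one, does not separate from compound 2, although that exchange alters both the group and its place on the ring. Nothing at hand explains why chloro and methyl read alike.

Going by these compounds, whether an ethyl, an amine or a carboxylic acid at this carbon would stay level with chloro and methyl remains open. Also open, on these data alone, is whether chloro and methyl would read alike on the core of compound 1.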